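Replacing the Nitrophenyl Group with a Cyanophenyl Group

The compounds below may be only part of what the source reports. "The series", "measured", "known", "first", "only" and "open" are said of these compounds alone.

Three compounds share one core. Compound 2 `COc1ccc(/C=C\C(=O)O)c(OCc2cn(-c3ccccc3)nn2)c1CC=C(C)C` carries an unsubstituted phenyl group, compound 3 `COc1ccc(/C=C\C(=O)O)c(OCc2cn(-c3cccc([N+](=O)[O-])c3)nn2)c1CC=C(C)C` a 3-nitrophenyl group, and compound 1 `COc1ccc(/C=C\C(=O)O)c(OCc2cn(-c3ccccc3I)nn2)c1CC=C(C)C` a 2-iodophenyl group. In a functional assay on T47D cells (Homo sapiens) for cytotoxicity, read by MTT assay, with a stated time of 24 h (on this read-out lower numbers stand for stronger inhibition and higher numbers for weaker inhibition), compound 2 gives 34100 nM and compound 3 gives 15400 nM; in the same assay compound 1 gives "not determined" (no result reported). Among the compounds with values here, the one measured step is a 2.2-fold lower number from compound 2 to compound 3 (0.35 log units; beyond the scatter). Compound 3 thus stands with the lowest of the two numbers, and compound 2 is its nearest neighbour with a higher number beyond the scatter.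

Compound 4 `COc1ccc(/C=C\C(=O)O)c(OCc2cn(-c3ccccc3C#N)nn2)c1CC=C(C)C` is the next analogue; its difference from compound 3 is 2-cyanophenyl in place of 3-nitrophenyl on an aromatic nitrogen. Within the data shown here, only one step bears on this change, and only loosely: a 2.2-fold lower number from compound 2 to compound 3 (0.35 log units; beyond the scatter) shows that adding a nitro group to the phenyl ring lowers the number modestly, whereas compound 4 removes that nitro and brings in a nitrile instead. Among the measured compounds shown here, no measured compound carries a nitrile, so there is no direct guide. Compound 4 is expected to lie between the numbers of the two measured compounds, with a step of a 1.4-fold higher number from compound 3 to compound 4 (0.15 log units; within the scatter) relative to the nitro analogue. The estimate for compound 4 in this assay is 22000 nM, within a range from 10000 nM to 45000 nM.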

Compound 4, half-maximal inhibitory concentration: 8800 nM
Beside the measured number, compound 4's estimate is 2.5-fold (0.40 log units) above it, outside the stated range (below it).
By their numbers in this assay, from the lowest: compounds 4 and 3 (each within the scatter of the next); then compound 2.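

In this assay the 2-cyanophenyl group gives a 3.9-fold lower number from compound 2 to compound 4 (0.59 log units; beyond the scatter) and so shows that a substituent other than nitro on the phenyl ring also goes with a lower number than the unsubstituted phenyl group of compound 2. Exchanging the 3-nitrophenyl group for the 2-cyanophenyl group gives a 1.8-fold lower number from compound 3 to compound 4 (0.24 log units; within the scatter) and leaves compound 3 and compound 4 indistinguishable in this assay, even though the two groups differ both in the substituent and in where it stands on the ring. Nothing measured here accounts for either step.

Nitrile and nitro each appear at only one place on the ring, so the contribution of the group cannot be separated from that of its place, and compound 1 with its 2-iodophenyl group has no number that could help. As far as these compounds go, whether an amine or a carboxylic acid on the phenyl ring would go with a number near those of compound 3 and compound 4, or nearer that of compound 2, also remains open.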